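A dihydroxyphenyl group replaces the halogens of compound 2

The compounds below may be only part of what the source reports. "The series", "measured", "known", "first", "only" and "open" are said of these compounds alone.

Measured in a functional assay on K562 cells (Homo sapiens) for antiproliferative activity, with a stated time of 72 h; on this read-out lower numbers stand for stronger inhibition and higher numbers for weaker inhibition:
- compound 1 `OC[C@H]1O[C@@H](n2cnc3c(NCc4ccc(F)c(F)c4F)ncnc32)[C@H](O)[C@@H]1O`: > 166000 nM, a limit
- compound 2 `OC[C@H]1O[C@@H](n2cnc3c(NCc4ccc(F)c(Cl)c4)ncnc32)[C@H](O)[C@@H]1O`: 5500 nM

For the measured compounds named here, compound 2, at 5500 nM, holds the only actual number in this small set. Compound 1 reports only a limit, > 166000 nM.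

The next compound, compound 3 `OC[C@H]1O[C@@H](n2cnc3c(NCc4cccc(O)c4O)ncnc32)[C@H](O)[C@@H]1O`, keeps the shared core and changes only the group on the saturated chain carbon bound to a nitrogen on an aromatic ring, with 2,3-dihydroxyphenyl in place of 3-chloro-4-fluorophenyl on a saturated chain carbon bound to a nitrogen on an aromatic ring.

Going by the values given here, one measured step bears on this change: an at least 30-fold lower number from compound 1 to compound 2 (1.47 log units; beyond the scatter). Its size rests on (the limit of > 166000 nM in this assay, at which 1 of the 2 values shown sits). That step exchanged a substituted phenyl group at the same place, so this group can move this assay a long way. Neither measured compound carries hydroxyl groups, however, so the step gives a size but no firm direction. A moderate move towards weaker inhibition is expected, with wide uncertainty. The expected change is a 2.7-fold higher number from compound 2 to compound 3 (0.44 log units; beyond the scatter). For compound 3 the estimate is 15000 nM, with an expected range of 2000 nM to 100000 nM.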

Compound 3, half-maximal inhibitory concentration: 25800 nM
Beside the measured number, compound 3's estimate is 1.7-fold (0.24 log units) below it; low and high end bracket the measured number.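

Compound 3 shows that a phenyl group bearing hydroxyl groups instead of halogens keeps measurable activity on a saturated chain carbon bound to a nitrogen on an aromatic ring, but at a cost: in this assay, 2,3-dihydroxyphenyl in place of 3-chloro-4-fluorophenyl gives a 4.7-fold higher number from compound 2 to compound 3 (0.67 log units; beyond the scatter). It also outperforms the trifluorinated group, with an at least 6.4-fold lower number from compound 1 to compound 3 (0.80 log units; beyond the scatter), so among these three groups the order from stronger to weaker inhibition runs 3-chloro-4-fluorophenyl, 2,3-dihydroxyphenyl, 2,3,4-trifluorophenyl, and the presence of halogens alone does not settle the number. The size of this second step is only a lower bound, and it rests on a limit: the limit of > 166000 nM in this assay, at which 1 of the 3 values shown sits.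

The compounds shown leave open whether a single hydroxyl group, or methoxy groups in place of the two hydroxyl groups, would give a number closer to that of compound 2 or that of compound 3. Also open, from the compounds shown here alone, is how a phenyl group carrying an amine or a carboxylic acid would read in this assay, and whether a lone chlorine would hold the activity of the 3-chloro-4-fluorophenyl group.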